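The compounds below may be only part of what the source reports. "The series", "measured", "known", "first", "only" and "open" are said of these compounds alone.

Measured so far:
compound 1, `N#Cc1ccc(/C=N/NC(=O)Nc2ccc(Oc3ccnc4[nH]ccc34)c(F)c2)cc1` — 850 nM
compound 2, `COc1cc(/C=N/NC(=O)Nc2ccc(Oc3ccnc4[nH]ccc34)c(F)c2)cc(OC)c1OC` — "not active" (no number reported)

Within the data shown here, in a functional assay on HepG2 cells (Homo sapiens) for antiproliferative activity, read by MTT assay, with a stated time of 72 h (on this read-out higher numbers stand for weaker inhibition and lower numbers for stronger inhibition), compound 1 gives 850 nM, the only number in this set. Among the measured compounds shown here, compound 2 is reported in this assay as "not active" (no number reported), with no figure attached, so no step between measured compounds can be sized. Compound 3, `O=C(N/N=C/c1ccc(O)c(Br)c1)Nc1ccc(Oc2ccnc3[nH]ccc23)c(F)c1`, has not yet been tested. It differs from compound 1 in one place: 3-bromo-4-hydroxyphenyl in place of 4-cyanophenyl on a carbon with a double bond to nitrogen. Without a measured pair for comparison, the direction of this change rests on little; the one failure seen, compound 2, shows that the group on this carbon can remove activity altogether. The step from compound 1 to compound 3 in this assay is therefore expected to be small, with weakening somewhat more likely than strengthening, and a real chance of no number at all. Compound 3 is estimated at 1500 nM, within 400 nM to 6000 nM, which is expected as a 1.8-fold higher number from compound 1 to compound 3 (0.25 log units; within the scatter).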

Compound 3, half-maximal inhibitory concentration: 1360 nM
The estimate for compound 3 lay 1.1-fold (0.04 log units) above the measured number; the measured number falls inside the stated range.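

In this assay, putting 3-bromo-4-hydroxyphenyl in place of 4-cyanophenyl on a carbon with a double bond to nitrogen gives a 1.6-fold higher number from compound 1 to compound 3 (0.20 log units; within the scatter), so this change does not separate the two compounds on this read-out. Compound 2 is reported as not active, whereas compound 3 keeps a measurable number, which shows that the loss seen in compound 2 is not shared by every substituted phenyl group at this place. Nothing available here offers a reason for this result.

From the compounds shown here alone, the bromine and the hydroxyl enter together, and what each does alone stays unknown. Also open, going by these compounds, is how this place would respond to a group of a different kind, such as an amine or a carboxylic acid in place of the aromatic ring.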